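The source may hold more compounds than are shown below. What is called first, only, known or untested is meant among the compounds shown, and "the series" means these compounds.

Measured in a functional assay on K562 cells (Homo sapiens) for cytotoxicity, read by MTT assay, with a stated time of 48 h; on this read-out lower numbers stand for stronger inhibition and higher numbers for weaker inhibition:
- Compound 1 `CCNC(=O)CC[C@H](NS(=O)(=O)c1ccc([N+](=O)[O-])cc1)C(=O)O`: > 500000 nM (a limit of the assay)
- Compound 2 `CC(C)NC(=O)CC[C@H](NS(=O)(=O)c1ccc([N+](=O)[O-])cc1)C(=O)O`: 19800 nM

For the measured compounds named here, compound 2, at 19800 nM, holds the only actual number so far. Compound 3 `O=C(CC[C@H](NS(=O)(=O)c1ccc([N+](=O)[O-])cc1)C(=O)O)NCc1ccccc1` differs from it by benzyl in place of isopropyl on an amide-type nitrogen, with benzyl in place of isopropyl on an amide-type nitrogen. Going by the values given here, one measured step bears on this: an at least 25-fold lower number from compound 1 to compound 2 (1.40 log units; beyond the scatter), a large change from methyl in place of hydrogen on a saturated chain carbon bound to that nitrogen. This single step, measured from a limit, suggests the direction only, so a modest further fall in this assay is expected. The expected change is a 2.0-fold lower number from compound 2 to compound 3 (0.30 log units; within the scatter). For compound 3 the estimated value is 10000 nM, with an expected range of 2500 nM to 50000 nM.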

Compound 3, half-maximal inhibitory concentration: 23400 nM
Estimate against measurement, compound 3: 2.3-fold (0.37 log units) below, within the range that was stated.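

In this assay benzyl on the amide-type nitrogen gives a 1.2-fold higher number from compound 2 to compound 3 (0.07 log units; within the scatter) and so stands level with isopropyl: this position takes a six-membered aromatic ring with no shift beyond the scatter. The other comparison shows an at least 21-fold lower number from compound 1 to compound 3 (1.32 log units; beyond the scatter) and so the large gap to compound 1 now holds for two different groups, not for isopropyl alone. Compound 1 alone carries a limit and not a number: the limit of > 500000 nM in this assay, at which 1 of the 3 values shown sits.

The compounds shown leave open whether a cyclohexyl group or a longer chain on that nitrogen would hold this level. They also leave open what a methyl ester in place of the carboxylic acid would do.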